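This account rests on a few compounds, and the source may have more. Where it says the series, first, only, none or still open, it means among the compounds named here.

Measured so far in an assay on LX2 cells for inhibition of COL1A1 promoter (Homo sapiens), read by a luciferase reporter, with a stated time of 24 h, tested at 50 uM; a higher number here means a stronger effect of the compound at the concentration tested, a lower number a weaker effect:
compound 1, `CN(C)c1ccc2c(=O)c(C(=O)Nc3cc(F)cc(F)c3)cn(-c3ccc(Cl)c(OCCCCCCC[N+]4(C)CCCCC4)c3)c2n1`, gives 90.5%
compound 2, `CN1CC[N+](C)(CCCCCCCOc2cc(-n3cc(C(=O)Nc4cc(F)cc(F)c4)c(=O)c4ccc(N(C)C)nc43)ccc2Cl)CC1`, gives 45.2%

Compound 2 stands at the lower of the two numbers; its nearest neighbour is compound 1, and the step of a number 45.3 percentage points lower from compound 1 to compound 2 (beyond the scatter) is large and beyond the scatter. That step exchanged a group of 7 heavy atoms (6 carbon, 1 nitrogen; one six-membered non-aromatic ring with 1 hetero atom) for a group of 8 heavy atoms (6 carbon, 2 nitrogen; one six-membered non-aromatic ring with 2 hetero atoms), on a saturated chain carbon, seven bonds along the chain from an oxygen on an aromatic ring.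

Compound 3, `CC[N+]1(CCCCCCCOc2cc(-n3cc(C(=O)Nc4cc(F)cc(F)c4)c(=O)c4ccc(N(C)C)nc43)ccc2Cl)CCCC1`, is not yet measured. It differs from compound 2 as follows: a group of 7 heavy atoms (6 carbon, 1 nitrogen; one five-membered non-aromatic ring with 1 hetero atom) in place of a group of 8 heavy atoms (6 carbon, 2 nitrogen; one six-membered non-aromatic ring with 2 hetero atoms), on a saturated chain carbon, seven bonds along the chain from an oxygen on an aromatic ring. The change sits at the same place as the measured step and brings the charged ring back to one with 1 hetero atom, now five-membered rather than six-membered. Within the data shown here, the only step that bears on it is a number 45.3 percentage points lower from compound 1 to compound 2 (beyond the scatter), which ran in the opposite direction to the present change; an upward step of comparable size is therefore expected in this assay, though the five-membered ring has no precedent and the size is uncertain. Compound 3 is estimated at 78% (range 50% to 95%), which means an expected step of a number 32.8 percentage points higher from compound 2 to compound 3 (beyond the scatter).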

Compound 3, a percentage reported as inhibition, at one concentration (the size of the read-out at that concentration, not a potency): 96.4%
Beside the measured number, compound 3's estimate is 18.4 percentage points below it, and the stated range ends below it.
By their numbers in this assay, from the lowest: compound 2; then compounds 1 and 3 (each within the scatter of the next).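

In this assay the lower number of compound 2 proves reversible at this position: a number 51.2 percentage points higher from compound 2 to compound 3 (beyond the scatter) when the one six-membered non-aromatic ring with 2 hetero atoms gives way to the one five-membered non-aromatic ring with 1 hetero atom. The two rings with 1 hetero atom do not separate, with a number 5.9 percentage points higher from compound 1 to compound 3 (within the scatter) and so no reading on ring size, even though the charged nitrogen also carries an ethyl group in compound 3 and a methyl group in compound 1. Among these three compounds, only compound 2 stands apart, so the link between the second ring nitrogen and the lower number rests on that single compound.

Still open, as far as these compounds go, is whether any second ring atom would give the same fall, as a morpholine ring with oxygen in that place would show, and whether the ethyl and methyl groups matter on an otherwise identical ring, since each number is the effect at one concentration and not a potency. Nothing available explains the difference between the ring with 2 hetero atoms and those with 1.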